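Solubility after swapping the acylated pyrrolidine nitrogen for an alkyl chain

This account rests on a few compounds, and the source may have more. Where it says the series, first, only, none or still open, it means among the compounds named here.

Compound 1 `CC(C)(C)OC(=O)N1CCC[C@H]1C(=O)N1CCC(NS(=O)(=O)c2cc(S(=O)(=O)c3ccccc3)ccc2C(F)(F)F)CC1` gives 25000 nM in a physicochemical assay for solubility; on this read-out lower numbers stand for lower solubility and higher numbers for higher solubility.
Compound 2 `CN(C)CC(=O)N1CCC[C@H]1C(=O)N1CCC(NS(=O)(=O)c2cc(S(=O)(=O)c3ccccc3)ccc2C(F)(F)F)CC1` gives 100000 nM in this assay.

In this assay compound 2 holds the higher of the two numbers, with compound 1 the nearest measured point. Compound 3 `CC(C)(C)CCN1CCC[C@H]1C(=O)N1CCC(NS(=O)(=O)c2cc(S(=O)(=O)c3ccccc3)ccc2C(F)(F)F)CC1` differs from compound 2 in one place: 3,3-dimethylbutyl in place of ((dimethylamino)methyl)carbonyl on an amine nitrogen in a ring. Going by the values given here, the only measured step at this position is a 4.0-fold higher number from compound 1 to compound 2 (0.60 log units; beyond the scatter), which shows this site moving the number beyond the scatter. The change to compound 3 removes what compound 2 gained there, so a modest downward step a 3.3-fold lower number from compound 2 to compound 3 (0.52 log units; beyond the scatter) is expected. Compound 3 is therefore estimated at 30000 nM, within 8000 nM to 100000 nM.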

Compound 3, solubility: 12500 nM
Compound 3: middle estimate off by 2.4-fold (0.38 log units), on the high side, and the stated range covers the measured number.
By their numbers in this assay, from the lowest: compounds 3 and 1 (each within the scatter of the next); then compound 2.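

In this assay, the 3,3-dimethylbutyl chain on this amine nitrogen does not hold the number seen with ((dimethylamino)methyl)carbonyl, giving an 8.0-fold lower number from compound 2 to compound 3 (0.90 log units; beyond the scatter). Set against tert-butoxycarbonyl, the same chain gives a 2.0-fold lower number from compound 1 to compound 3 (0.30 log units; within the scatter), so compound 1 and compound 3 cannot be told apart here, although only the group in compound 1 has a carbonyl. No measurement shown gives a reason for either step.

Still open, on these data alone, is whether the step in compound 2 goes with its dimethylamino group or with its carbonyl. An alkyl chain ending in a dimethylamino group, with no carbonyl, would separate the two.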